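Aryl groups on sulfur: from compound 3 to compound 4

This account rests on a few compounds, and the source may have more. Where it says the series, first, only, none or still open, it means among the compounds named here.

Measured in a functional assay on SMMC-7721 cells (Homo sapiens) for inhibition, read by CCK-8 assay, with a stated time of 72 h, tested at 8 uM; on this read-out lower numbers stand for less inhibition of growth and higher numbers for more inhibition of growth at the one concentration tested:
compound 1 `Cc1cc(C)cc(SCc2ccc(/C=C/C(=O)Nc3ccccc3N)cc2)c1`: 7.13%
compound 2 `CCc1ccc(SCc2ccc(/C=C/C(=O)Nc3ccccc3N)cc2)cc1`: 19.5%
compound 3 `Nc1ccccc1NC(=O)/C=C/c1ccc(CSc2ccc(C(F)(F)F)cn2)cc1`: 20.1%

Compound 3 cannot be told apart from compound 2: a number 0.6 percentage points higher from compound 2 to compound 3 (within the scatter). Compound 1 lies clearly lower: a number 13 percentage points higher from compound 1 to compound 3 (beyond the scatter). The next analogue, compound 4 `Cc1ccc(SCc2ccc(/C=C/C(=O)Nc3ccccc3N)cc2)cc1`, carries this change: 4-methylphenyl in place of 5-(trifluoromethyl)pyridin-2-yl on a sulfur. The nearest measured group is the 4-ethylphenyl of compound 2, and the other bearing step is a number 12.4 percentage points higher from compound 1 to compound 2 (beyond the scatter). Changing the group on sulfur has therefore moved the number by a modest amount at most in this set. Only a small fall in this assay, within the scatter, is expected: a number 4.1 percentage points lower from compound 3 to compound 4 (within the scatter). The expected value for compound 4 is 16%, with an estimated range from 6% to 26%.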

Compound 4, percent growth inhibition at one concentration: 22.2%
Estimate against measurement, compound 4: 6.2 percentage points below, within the range that was stated.
By their numbers in this assay, from the lowest: compound 1; then compounds 2, 3 and 4 (each within the scatter of the next).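

In this assay, a 4-methylphenyl on sulfur cannot be told apart from the 5-(trifluoromethyl)pyridin-2-yl (a number 2.1 percentage points higher from compound 3 to compound 4 (within the scatter)), so a ring of carbon only and a ring with a hetero atom read alike in this set. The 4-ethylphenyl and 4-methylphenyl are likewise not separated (a number 2.7 percentage points higher from compound 2 to compound 4 (within the scatter)), whereas the 3,5-dimethylphenyl stands apart (a number 15.1 percentage points higher from compound 1 to compound 4 (beyond the scatter)). No available evidence bears on these steps. Still open, from the compounds shown here alone, is how an amine or a carboxylic acid in place of these aryl groups on sulfur would read, and whether a longer chain than ethyl on the phenyl ring would differ from these compounds.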